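The source may hold more compounds than are shown below. What is called first, only, known or untested is meant among the compounds shown, and "the series" means these compounds.

Measured compounds in a functional assay on MDA-MB-231 cells (Homo sapiens) for antiproliferative activity, read by CCK-8 assay, with a stated time of 72 h; on this read-out lower numbers stand for stronger inhibition and higher numbers for weaker inhibition:
compound 1, `O=C(Nc1cccc(-c2oc3cc(-c4ccc(F)cc4)ccc3c(=O)c2O)c1)c1ccccc1F`, gives 7240 nM
compound 2, `O=C(Nc1cccc(-c2oc3cc(-c4ccc(F)cc4)ccc3c(=O)c2O)c1)c1ccc(Cl)cc1`, gives 12800 nM
compound 3, `Cc1cccc(C(=O)Nc2cccc(-c3oc4cc(-c5ccc(F)cc5)ccc4c(=O)c3O)c2)c1`, gives 2840 nM

All three share the same core and differ only in the aryl on the carbonyl carbon of the amide. Compound 3 stands lowest of the three numbers in this assay: the step of a 2.5-fold lower number from compound 1 to compound 3 (0.41 log units; beyond the scatter) and the step of a 4.5-fold lower number from compound 2 to compound 3 (0.65 log units; beyond the scatter) both lie beyond the scatter, whereas the step of a 1.8-fold higher number from compound 1 to compound 2 (0.25 log units; within the scatter) does not.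

Compound 4, `CCc1ccc(C(=O)Nc2cccc(-c3oc4cc(-c5ccc(F)cc5)ccc4c(=O)c3O)c2)cc1`, is the next variation at the same place: 4-ethylphenyl in place of 3-methylphenyl on a carbonyl carbon. For the measured compounds named here, no measured pair covers this exact exchange. Going by the values given here, the steps that bear on it are the two leading to compound 3, both modest in size, which suggests that swapping one simple aryl for another at this carbonyl carbon moves this assay by a modest amount at most. Compound 2, which also carries a 4-substituted phenyl here, gave the highest number of the three, so a somewhat higher number than compound 3 is expected for compound 4, estimated as a 1.9-fold higher number from compound 3 to compound 4 (0.29 log units; within the scatter). Compound 4 is thus expected to give about 5500 nM in this assay, within a range of 2000 nM to 15000 nM.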

Compound 4, half-maximal inhibitory concentration: 9070 nM
For compound 4 the middle estimate is 1.6-fold (0.22 log units) below the measured one, and the stated range covers the measured number.
By their numbers in this assay, from the lowest: compound 3; then compounds 1, 4 and 2 (each within the scatter of the next).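

In this assay the exchange of 3-methylphenyl for 4-ethylphenyl on the carbonyl carbon gives a 3.2-fold higher number from compound 3 to compound 4 (0.50 log units; beyond the scatter), so the low number of compound 3 does not carry over to this other alkyl-substituted phenyl. With ethyl in place of chloro on an aromatic carbon there is a 1.4-fold lower number from compound 2 to compound 4 (0.15 log units; within the scatter), and the exchange of 2-fluorophenyl for 4-ethylphenyl gives a 1.3-fold higher number from compound 1 to compound 4 (0.10 log units; within the scatter); both steps lie within the scatter, which leaves 3-methylphenyl as the only aryl among these four that stands apart. Nothing available explains any of these steps.

Still open, from the compounds shown here alone, is whether the number of compound 3 depends on the methyl group or on where it sits, a question that 4-methylphenyl and 3-ethylphenyl would separate. Also open, going by these compounds, is how this assay responds to an amine, a carboxylic acid or a longer alkyl chain on this phenyl.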